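The source may report more compounds than this note shows. Statements on the series, on what has been measured and on what is new or still open speak of the compounds shown alone.

In a functional assay on A549 cells (Homo sapiens) for cytotoxicity, read by MTT assay, with a stated time of 72 h (a higher number here means a weaker inhibitor, a lower number a stronger inhibitor), compound 1 `Nc1cccc(Nc2nc3ccccc3nc2S(=O)(=O)c2ccccc2)c1`, with a 3-aminophenyl on the nitrogen of the shared core, gives 1590 nM. Compound 2 `O=S(=O)(c1ccccc1)c1nc2ccccc2nc1Nc1ccc(F)cc1` carries a 4-fluorophenyl there, and its > 50000 nM is a limit of the assay, not a number. Compound 3 `O=S(=O)(c1ccccc1)c1nc2ccccc2nc1Nc1ccc(C(F)(F)F)cc1` carries a 4-(trifluoromethyl)phenyl, and its > 50000 nM is also a limit. Compound 2 therefore stands at the limit of > 50000 nM in this assay, at which 2 of the 3 values shown sit.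

Compound 4 `Cc1ccc(S(=O)(=O)c2nc3ccccc3nc2Nc2ccc(F)cc2)cc1` keeps the 4-fluorophenyl of compound 2 and changes elsewhere, with the phenyl becoming a 4-methylphenyl: methyl in place of hydrogen on an aromatic carbon. Within the data shown here, no measured step tests this methyl in place of hydrogen on an aromatic carbon. The nearest evidence is an at least 31-fold higher number from compound 1 to compound 2 (1.49 log units; beyond the scatter) and an at least 31-fold higher number from compound 1 to compound 3 (1.49 log units; beyond the scatter). Both are large, but both change the group on the nitrogen. The step that the two limits leave unreadable from compound 2 to compound 3 adds little, as it joins two limits.

Among these compounds, a real number appears only for compound 1, at 1590 nM, and compound 4 lacks its 3-aminophenyl. No step beyond the scatter is therefore expected, and a reading at the same limit is the likeliest result. The expected step is a number no higher from compound 2 to compound 4 (the limit leaves the size open). For compound 4 the estimated value is 50000 nM, with an expected range from 20000 nM to 100000 nM.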

Compound 4, half-maximal inhibitory concentration: 39200 nM
Beside the measured number, compound 4's estimate is 1.3-fold (0.11 log units) above it; the measured number falls inside the stated range.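

The change from phenyl to 4-methylphenyl is the first one shown that lies outside the group on the nitrogen, and it gives an at least 1.2-fold lower number from compound 2 to compound 4 (0.10 log units; that floor lies within the scatter). With a methyl at this place, para to a large group, compound 4 has a readable number in this assay, so the methyl does not push the compound out of the measurable range, but the floor of this step is too small to show that the methyl changes anything. Compound 2 remains a limit of the assay and not a number: the limit of > 50000 nM in this assay, at which 2 of the 4 values shown sit.

Going by these compounds, the true size of the step stays open, and so does whether the same methyl would have a similar effect on compound 1, with its 3-aminophenyl on the nitrogen. An amine or a carboxylic acid in place of the methyl would help to show whether this position affects the number at all, since for now it rests on a single change.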